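A Methoxy Added to the Phenyl Ring of Compound 3

The source may report more compounds than this note shows. Statements on the series, on what has been measured and on what is new or still open speak of the compounds shown alone.

Three compounds have so far been run in a functional assay on U-87MG ATCC cells for antiproliferative activity against U-87 MG (Homo sapiens), read by MTT assay, with a stated time of 48 h, tested at 10 uM; on this read-out lower numbers stand for a stronger effect and higher numbers for a weaker effect at the one concentration tested. Compound 1 `COc1ccc(-c2nc(C)c(C(=O)CSc3nc(N)c(C#N)c(-c4ccc(Cl)cc4)n3)s2)cc1` gives 44% in this assay. Compound 2 `Cc1nc(-c2ccc(Cl)cc2)sc1C(=O)CSc1nc(-c2ccccc2)c(C#N)c(=O)[nH]1` gives 83.1%. Compound 3 `COc1ccc(-c2nc(SCC(=O)c3sc(-c4ccccc4)nc3C)[nH]c(=O)c2C#N)cc1` gives 90.4%, the highest of the three numbers, though the number of compound 2 lies within the usual scatter of it, so the two cannot be told apart; the number of compound 1 lies far below, well beyond the scatter. Compound 3 therefore shows only a weak effect at the single concentration tested.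

Compound 4 `COc1ccc(-c2nc(C)c(C(=O)CSc3nc(-c4ccc(OC)cc4)c(C#N)c(=O)[nH]3)s2)cc1` has not yet been measured. It differs from compound 3 in one place: methoxy in place of hydrogen on an aromatic carbon. The change sits on an aromatic carbon of a six-membered aromatic ring of carbon only, para to a large group; read one bond further out, it turns phenyl into 4-methoxyphenyl. For the measured compounds named here, no measured pair shows this same change, so no measured step can be borrowed, and the two compounds that share the core of compound 3, compounds 2 and 3, give numbers within the scatter of each other. For compound 4 a step of a number 2.4 percentage points lower from compound 3 to compound 4 (within the scatter) is expected, small and not beyond the scatter. Compound 4 is accordingly estimated at 88%, with a range from 74% to 100%.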

Compound 4, a percentage reported as activity, at one concentration (the size of the read-out at that concentration, not a potency): 80.3%
Estimate against measurement, compound 4: 7.7 percentage points above; the measured number falls inside the stated range.
By their numbers in this assay, from the lowest: compound 1; then compounds 4, 2 and 3 (each within the scatter of the next, the first and the last beyond it).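

In this assay, for the compounds shown here, the change from phenyl to 4-methoxyphenyl gives a number 10.1 percentage points lower from compound 3 to compound 4 (beyond the scatter), the first step in this set that can be read at a single place, as no earlier pair differed in one place only. It shows that this position, on an aromatic carbon para to a large group, responds to substitution: methoxy in place of hydrogen moves the number modestly toward a stronger effect, although compound 4 at 80.3% still shows only a weak effect at the one concentration tested. Nothing at hand bears on the reason for this step, so it stands as an observation only.

The compounds shown do not tell whether this step is particular to methoxy or would also appear with another group at the same place, such as a hydroxyl, a fluorine atom, or the longer ethoxy chain. They also leave open whether the same change would give a step of similar size on the core of compound 1, which already gives a much lower number.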